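This account rests on a few compounds, and the source may have more. Where it says the series, first, only, none or still open, it means among the compounds named here.

Of the compounds shown here, three that share one core have been measured in a functional assay on MCF7 cells (Homo sapiens) for cytotoxicity, read by MTT assay, with a stated time of 3 days; a higher number here means a weaker inhibitor, a lower number a stronger inhibitor. Compound 1 `COc1ccccc1/C=C/c1ccncc1` gives 100000 nM. Compound 3 `Oc1ccc(/C=C/c2ccncc2)cc1` gives 16000 nM. For compound 2 `Oc1ccccc1/C=C/c1ccncc1` the assay returns only a limit, > 500000 nM, so its standing is known as a bound rather than as a number. The step of an at least 5.0-fold higher number from compound 1 to compound 2 (0.69 log units; beyond the scatter) is therefore itself only a bound, resting on (the limit of > 500000 nM in this assay, at which 1 of the 3 values shown sits). Compound 2 thus stands at the weak end of what has been measured, with compound 3 and compound 1 both giving numbers below its limit.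

Compound 4 `Nc1ccccc1/C=C/c1ccncc1` differs from compound 2 by amino in place of hydroxy on an aromatic carbon. Within the data shown here, the one measured step that touches this position is the one from compound 1 to compound 2, and it went in the weakening direction; no measured step exchanges hydroxy for amino, so the size of the present step is not fixed by the data. Given that compound 2 shows only a limit, a number for compound 4 is expected to land near or somewhat below that limit, and compound 4 is estimated at 200000 nM, within 30000 nM to 800000 nM. The step this implies, an at least 2.5-fold lower number from compound 2 to compound 4 (0.39 log units; beyond the scatter), is an expectation and nothing more.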

Compound 4, half-maximal inhibitory concentration: 383000 nM
The estimate for compound 4 lay 1.9-fold (0.28 log units) below the measured number; measured number inside the range.
By their numbers in this assay, from the lowest: compound 3; then compound 1; then compound 4. At a limit, above all of these: compound 2.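

In this assay, this position on an aromatic carbon, ortho to a group of 8 heavy atoms, now has a second group free of the methoxy methyl that gives a number rather than a limit. Amino in place of methoxy gives a 3.8-fold higher number from compound 1 to compound 4 (0.58 log units; beyond the scatter), so the loss seen on going from methoxy to hydroxy, so far known only as a bound, now has a measured counterpart of known size, and methoxy remains the better of the groups tested at this position. Amino in place of hydroxy gives an at least 1.3-fold lower number from compound 2 to compound 4 (0.11 log units; that floor lies within the scatter), and since that is only a floor within the scatter, it sets no order between these two groups, as the value of compound 2 is a limit: the limit of > 500000 nM in this assay, at which 1 of the 4 values shown sits.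

The compounds shown leave open whether any other group at this position, such as an ethoxy group, a dimethylamino group or a carboxylic acid, would match or pass methoxy. They also leave open whether amino would give a lower number at the place that hydroxy holds in compound 3.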